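The source may report more compounds than this note shows. Statements on the series, on what has been measured and on what is new or still open speak of the compounds shown alone.

Compound 1 `Cc1ccsc1-c1cc(-c2ccco2)cc(-c2ccccc2Cl)n1` gives 2%
Compound 2 `Cc1ccsc1-c1cc(-c2ccco2)cc(-c2ccc(Cl)cc2)n1` gives 1%
Compound 3 `Cc1ccsc1-c1cc(-c2ccoc2)cc(-c2ccco2)n1` gives 5.4%

In an assay on isolated protein for inhibition of DNA topoisomerase 1 (Homo sapiens), with a stated time of 30 min, tested at 100 uM (a higher number here means more inhibition at the concentration tested (going by the name of the read-out), a lower number less inhibition), compound 3 stands highest of the three numbers, but its gaps to compound 1 and to compound 2 both lie within the scatter, so all three values sit close together and none can be called stronger than another. Compound 4 `Cc1ccsc1-c1cc(-c2ccoc2)cc(-c2ccc(Cl)cc2)n1` differs from compound 3 by 4-chlorophenyl in place of furan-2-yl on an aromatic carbon. Among the measured compounds shown here, the only measured step, a number 1 percentage points lower from compound 1 to compound 2 (within the scatter), concerns a change of position of chlorine on a phenyl ring, not the exchange of a furan-2-yl for a 4-chlorophenyl, so no measured step bears directly on this change. For the measured compounds named here, since every value so far is small and every step stayed within the scatter, compound 4 is expected to show no step beyond the scatter, a number 2.4 percentage points lower from compound 3 to compound 4 (within the scatter). Compound 4 is therefore estimated at 3%, within 0% to 12%.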

Compound 4, a percentage reported as inhibition, at one concentration (the size of the read-out at that concentration, not a potency): 85.9%
The estimate for compound 4 lay 82.9 percentage points below the measured number; the measured number lies above the stated range.
By their numbers in this assay, from the lowest: compounds 2, 1 and 3 (each within the scatter of the next); then compound 4.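

In this assay, putting 4-chlorophenyl next to the ring nitrogen gives a number 80.5 percentage points higher from compound 3 to compound 4 (beyond the scatter), with furan-3-yl present on the shared core in both compounds. Keeping 4-chlorophenyl and exchanging the other ring gives a number 84.9 percentage points higher from compound 2 to compound 4 (beyond the scatter), so the high number comes only with furan-3-yl and 4-chlorophenyl together, not with either group alone among these compounds. Nothing available explains this dependence.

Going by these compounds, what a plain phenyl or a 4-aminophenyl group would give at this place remains open. So does whether 2-chlorophenyl would match 4-chlorophenyl alongside furan-3-yl.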